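A Chloro Added to the Benzoyl Ester

A few compounds are considered here, and "the series" means these few. Any claim that something is new, unique, unknown or untested is made for them only; others in the source may bear on it.

compound 1 `CN(C)CC1CCC/C(=C\c2ccc(OC(=O)/C=C/c3ccccc3)cc2)C1=O`: 32800 nM
compound 2 `CN(C)CC1CCC/C(=C\c2ccc(OC(=O)c3ccccc3)cc2)C1=O`: 23400 nM

In a functional assay on L1210 cells (Mus musculus) (a higher number here means a weaker inhibitor, a lower number a stronger inhibitor), compound 2 gives 23400 nM, the lower of the two numbers, but the step of a 1.4-fold lower number from compound 1 to compound 2 (0.15 log units; within the scatter) lies within the scatter, so compound 1 and compound 2 cannot be told apart. Compound 3 `CN(C)CC1CCC/C(=C\c2ccc(OC(=O)c3ccc(Cl)cc3)cc2)C1=O` differs from compound 2 by chloro in place of hydrogen on an aromatic carbon. Among the compounds with values here, no measured step concerns this change; the only step available, a 1.4-fold lower number from compound 1 to compound 2 (0.15 log units; within the scatter), alters a different part and stays within the scatter. Little movement is therefore expected. Compound 3 is estimated at 18000 nM, between 7000 nM and 45000 nM, an expected step of a 1.3-fold lower number from compound 2 to compound 3 (0.11 log units; within the scatter) that should stay within the scatter.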

Compound 3, half-maximal inhibitory concentration: 5610 nM
Beside the measured number, compound 3's estimate is 3.2-fold (0.51 log units) above it, and the stated range ends above it.
By their numbers in this assay, from the lowest: compound 3; then compounds 2 and 1 (each within the scatter of the next).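

Chloro in place of hydrogen on an aromatic carbon is the first change here to move the number beyond the scatter in this assay, with a 4.2-fold lower number from compound 2 to compound 3 (0.62 log units; beyond the scatter). Measured against the 2-phenylethenyl ester, the 4-chlorophenyl group gives a 5.8-fold lower number from compound 1 to compound 3 (0.77 log units; beyond the scatter), so this end of the molecule does respond to substitution. No other measurement bears on this result. From the compounds shown here alone, whether bromo, methoxy or an amine at the same carbon would give a similar step stays open, as does the effect of chloro on another carbon of that ring.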